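A few compounds are considered here, and "the series" means these few. Any claim that something is new, unique, unknown or untested is made for them only; others in the source may bear on it.

Compound 1 `C=Cc1cccc(C(=O)N2CCCC(C(=O)Nc3ccc(Cl)cc3)C2)c1`: 0%
Compound 2 `O=C(Nc1cccc(OCCc2ccccn2)c1)C1CCCN(C(=O)c2cc(C(F)(F)F)cc(C(F)(F)F)c2)C1`: 5%
Compound 3 `COC(=O)c1cc(-c2cccc(NC(=O)C3CCCN(C(=O)c4cc(C(F)(F)F)cc(C(F)(F)F)c4)C3)c2)co1`: 0%

All three compounds share one core and were tested in an ADME assay on PC-3 cells (Homo sapiens) for cytotoxicity, read by WST assay, tested at 100 uM; a higher number here means more inhibition at the concentration tested (going by the name of the read-out), a lower number less inhibition. In this assay compound 1 gives 0%, the same number at the digits shown as compound 3, and compound 2 lies within the usual scatter of both, so the three values cannot be told apart. Compound 4 `COCc1cccc(C(=O)N2CCCC(C(=O)Nc3ccc(Cl)cc3)C2)c1` is the next compound in the set. Compared with compound 1 it carries methoxymethyl in place of vinyl on an aromatic carbon. Among the compounds with values here, only one measured step exists among the three compounds, a number 5 percentage points lower from compound 2 to compound 3 (within the scatter); it exchanges a different group at a different aromatic carbon, and it stayed within the scatter. Within the data shown here, it offers no direct guide to the exchange of vinyl for methoxymethyl, and no compound here reaches beyond the scatter. Compound 4 is therefore expected to show no step beyond the scatter, a number 2 percentage points higher from compound 1 to compound 4 (within the scatter). Compound 4 is estimated to give 2%, with a likely range from 0% to 12%.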

Compound 4, a percentage reported as inhibition, at one concentration (the size of the read-out at that concentration, not a potency): 0%
Compound 4: the middle estimate sits 2 percentage points above what was measured; low and high end bracket the measured number.
By their numbers in this assay, from the lowest: compounds 1, 3, 4 and 2 (each within the scatter of the next).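

Exchanging vinyl for methoxymethyl on this aromatic carbon, meta to a large group, gives no change at the digits printed from compound 1 to compound 4 (within the scatter) in this assay. Within the data shown here, the earlier step changed a different group at a different aromatic carbon, so this is the first direct reading at this position. It shows that losing the double bond and adding an oxygen, a hydrogen-bond acceptor, leaves this cytotoxicity measure unmoved at the tested concentration, and no measurement of any property of these groups is at hand to explain that.

On these data alone, it remains open whether an amine, a carboxylic acid or a longer ether chain at this position would lift the number in this assay. Also open, as far as these compounds go, is whether the same exchange would read alike on the trifluoromethyl-bearing cores of compound 2 and compound 3.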